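A Second Chloro Group Joins an Anticonvulsant Series

This account rests on a few compounds, and the source may have more. Where it says the series, first, only, none or still open, it means among the compounds named here.

Measured so far:
Compound 1, `Cc1nn2cnnc2cc1Cc1ccccc1`, gives 9.5 mg/kg in a functional assay on the whole organism with Mus musculus as the target, in the maximal electroshock model; a lower number here means that less compound is needed, a higher number that more compound is needed for the effect.
Compound 2, `Cc1nn2cnnc2cc1Cc1ccccc1Cl`, gives 6 mg/kg in this assay.
Compound 3, `Cc1nn2c(N)nnc2cc1Cc1ccccc1Cl`, gives 17.4 mg/kg in this assay.

The change chloro in place of hydrogen on an aromatic carbon brings a 1.6-fold lower number from compound 1 to compound 2 (0.20 log units; within the scatter). An amino group then takes the place of hydrogen on an aromatic carbon, with a 2.9-fold higher number from compound 2 to compound 3 (0.46 log units; beyond the scatter). The difference between the cores of compound 1 and compound 3 is not broken down here. Compound 4, `Cc1nn2c(N)nnc2cc1Cc1c(Cl)cccc1Cl`, is not yet measured; it differs from compound 3 by chloro in place of hydrogen on an aromatic carbon. Within the data shown here, this is the same kind of change as the one leading to compound 2, though here the place is also meta to a chloro group. Resting on a 1.6-fold lower number from compound 1 to compound 2 (0.20 log units; within the scatter), a step of similar size is expected: a 1.3-fold lower number from compound 3 to compound 4 (0.13 log units; within the scatter). Compound 4 is therefore estimated at 13 mg/kg, between 6 mg/kg and 30 mg/kg.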

Compound 4, dose for half-maximal effect: 9.2 mg/kg
Compound 4: the middle estimate sits 1.4-fold (0.15 log units) above what was measured; measured number inside the range.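

In this assay, a second chloro group on the aromatic ring brings a 1.9-fold lower number from compound 3 to compound 4 (0.28 log units; within the scatter). The same change on two cores gives two steps that cannot be told apart: the same change on two cores in this assay, a 1.6-fold lower number (0.20 log units; within the scatter) from compound 1 to compound 2 and a 1.9-fold lower number (0.28 log units; within the scatter) from compound 3 to compound 4, 1.2-fold (0.08 log units) apart, within the scatter of two such steps. The change therefore carries over from one core to the other with no visible difference, but each step alone lies within the scatter, so neither shows a real effect of the chloro group, and two pairs say nothing about other cores.

The compounds shown leave open whether a fluoro or methoxy group would behave like chloro in this place. They also leave open how a methyl group or a longer chain would compare with the amino group on the core.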